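What one chloro may do to compound 2

The source may report more compounds than this note shows. Statements on the series, on what has been measured and on what is new or still open speak of the compounds shown alone.

In a functional assay on MDA-MB-231 cells (Homo sapiens) for antiproliferative activity, read by sulforhodamine B assay, with a stated time of 72 h (a lower number here means a stronger inhibitor, a higher number a weaker inhibitor), compound 1 `FC(F)(F)c1cccc(/C=C\c2cc3ccccc3nc2Cl)c1` gives 3750 nM and compound 2 `FC(F)(F)c1cc(/C=C\c2cc3ccccc3nc2Cl)cc(C(F)(F)F)c1` gives 10100 nM, the higher number of the two and so the weaker inhibitor. Compound 3 `FC(F)(F)c1cc(/C=C\c2cc3ccc(Cl)cc3nc2Cl)cc(C(F)(F)F)c1` differs from compound 2 in a single place, with chloro in place of hydrogen on an aromatic carbon. Going by the values given here, only one measured step bears on this, and only loosely. Putting trifluoromethyl in place of hydrogen on an aromatic carbon gave a 2.7-fold higher number from compound 1 to compound 2 (0.43 log units; beyond the scatter), a modest change. That step involves another group at another place, so it does not settle the direction for chloro. No step beyond the scatter is expected here, and the expected change is a 1.1-fold lower number from compound 2 to compound 3 (0.05 log units; within the scatter). For compound 3 the estimated value is 9000 nM, with an expected range of 3000 nM to 25000 nM.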

Compound 3, half-maximal inhibitory concentration: > 50000 nM
Compound 3 ended at the assay's limit (the forecaster's own chance of this, stated with the estimate: 10%); at least 5.5-fold (0.74 log units) between middle value and limit.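

In this assay compound 3 gives > 50000 nM, which is a limit of the assay and not a number: the limit of > 50000 nM in this assay, at which 1 of the 3 values shown sits. Chloro in place of hydrogen at this place on the fused system gives an at least 4.9-fold higher number from compound 2 to compound 3 (0.69 log units; beyond the scatter), so the true size of the change is known only as a minimum. The earlier step concerned trifluoromethyl at another place, whereas this one shows that activity in this assay also responds to this position, and that one heavy atom here is enough to weaken compound 2 beyond the scatter.

The compounds shown leave open whether any group at this position would weaken activity or whether this applies to chloro alone, a question that fluoro, methoxy or an amine there could answer. They also leave open whether the same chloro would have a similar effect on compound 1.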